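This account rests on a few compounds, and the source may have more. Where it says the series, first, only, none or still open, it means among the compounds named here.

Working notes on the series in a functional assay on Bel7402/5-FU cells (Homo sapiens) for antiproliferative activity, read by MTT assay, with a stated time of 72 h; a lower number here means a stronger inhibitor, a higher number a weaker inhibitor. Compound 1 (`COc1ccc(Cn2c(C(=O)O)c(CNCc3ccc(O)c(OC)c3)c3ccc(C(C)C)cc32)cc1`) gives 7900 nM, and compound 2 (`COc1ccc(Cn2c(C(=O)O)c(CN(C)Cc3cccc(OC)c3)c3ccc(C)cc32)cc1`) gives 7470 nM. Compound 3 (`COc1ccc(Cn2c(C(=O)O)c(CNCc3cccc(O)c3)c3ccc(C(C)C)cc32)cc1`) gives 15200 nM, within the scatter of compound 1 and beyond the scatter of compound 2, on the higher side. Compound 4 (`COc1ccc(Cn2c(C(=O)O)c(CNCc3cccc(O)c3)c3ccc(C)cc32)cc1`) follows from compound 3 with methyl in place of isopropyl on an aromatic carbon. Among the compounds with values here, the one measured step, a 1.9-fold higher number from compound 1 to compound 3 (0.28 log units; within the scatter), changes another group and gives no direct guide to this change. Compound 2 carries methyl there, but it differs from compound 3 elsewhere too, so compound 2 with 7470 nM is only a loose pointer toward lower numbers. No step beyond the scatter is expected, and the expected step is a 1.4-fold lower number from compound 3 to compound 4 (0.14 log units; within the scatter). Compound 4 is estimated at 11000 nM, with an expected range of 5000 nM to 24000 nM.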

Compound 4, half-maximal inhibitory concentration: > 50000 nM
Compound 4 was reported as a limit; the forecaster's own chance of this, stated with the estimate: 3%; middle value at least 4.5-fold (0.65 log units) from the limit.
By their numbers in this assay, from the lowest: compounds 2, 1 and 3 (each within the scatter of the next, the first and the last beyond it). At a limit, above all of these: compound 4.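

Compound 4 is reported only as a limit of the assay, not as a number: the limit of > 50000 nM in this assay, at which 1 of the 4 values shown sits. The isopropyl group on this aromatic carbon therefore matters when the (3-hydroxybenzyl)amino group is present, with methyl in its place giving an at least 3.2-fold higher number from compound 3 to compound 4 (0.51 log units; beyond the scatter). Methyl alone does not fix the outcome, since changing the amine with methyl held constant gives an at least 6.6-fold higher number from compound 2 to compound 4 (0.82 log units; beyond the scatter).

From the compounds shown here alone, whether an ethyl or a cyclopropyl group on this carbon would keep the number of compound 3 stays open. So does the effect of isopropyl alongside the (3-methoxybenzyl)(methyl)amino group.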